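Trading a benzofuran for a bare furan

This account rests on a few compounds, and the source may have more. Where it says the series, first, only, none or still open, it means among the compounds named here.

Compound 3 `Cc1nc(N)c2c(-c3cc4ccccc4o3)cn([C@@H]3O[C@H](CO)[C@@H](O)[C@H]3O)c2n1` shows the lower of the two numbers given in a functional assay on HCT-116 cells (Homo sapiens), read by MTT assay, with a stated time of 72 h (a lower number here means a stronger inhibitor, a higher number a weaker inhibitor), at 13100 nM; compound 1 `Nc1nc(N)c2c(-c3cc4ccccc4o3)cn([C@@H]3O[C@H](CO)[C@@H](O)[C@H]3O)c2n1` sits close by at 14000 nM, and the step of a 1.1-fold lower number from compound 1 to compound 3 (0.03 log units; within the scatter) lies within the scatter. Compound 2 `COc1ncnc2c1c(-c1ccccc1)cn2[C@@H]1O[C@H](CO)[C@@H](O)[C@H]1O` gives only a limit of the assay, > 20000 nM, which is the limit of > 20000 nM in this assay, at which 1 of the 3 values shown sits. Compound 4 `Cc1nc(N)c2c(-c3ccoc3)cn([C@@H]3O[C@H](CO)[C@@H](O)[C@H]3O)c2n1` differs from compound 3 in one place: furan-3-yl in place of 1-benzofuran-2-yl on an aromatic carbon. Among the compounds with values here, no measured step touches this change; the only measured step, a 1.1-fold lower number from compound 1 to compound 3 (0.03 log units; within the scatter), concerns another position and was flat. Compound 2, whose value is a limit, > 20000 nM, is the sole hint that a smaller aryl group weakens inhibition. On that basis compound 4 is estimated at 22000 nM, within 7000 nM to 70000 nM, an expected step of a 1.7-fold higher number from compound 3 to compound 4 (0.23 log units; within the scatter).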

Compound 4, half-maximal inhibitory concentration: > 20000 nM
Compound 4 ended at the assay's limit (the forecaster's own chance of this, stated with the estimate: 45%); the middle value is on the limit's open side.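

Within the data shown here, exchanging 1-benzofuran-2-yl for furan-3-yl on this aromatic carbon gives the only measured step at this position: an at least 1.5-fold higher number from compound 3 to compound 4 (0.18 log units; that floor lies within the scatter) in this assay. The value of compound 4 is a limit of the assay, so this step is only a floor and does not establish a change beyond the scatter. Compound 4 nevertheless reaches that limit: the limit of > 20000 nM in this assay, at which 2 of the 4 values shown sit.

From the compounds shown here alone, it remains open whether the result follows from losing the six-membered aromatic ring or from the changed point of attachment. A furan-2-yl group at this place would separate the two.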